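The source may report more compounds than this note shows. Statements on the series, on what has been measured and on what is new or still open speak of the compounds shown alone.

Compound 1 `CCCCCC(=O)Nc1ccc(S(=O)(=O)Oc2ccccc2I)cc1` and compound 2 `CC(C)(C)C(=O)Nc1ccc(S(=O)(=O)Oc2ccccc2I)cc1` share one core and differ only in the group on the carbonyl carbon. In a functional assay on M21 cells (Homo sapiens) for antiproliferative activity, read by sulforhodamine B assay, with a stated time of 48 h (a higher number here means a weaker inhibitor, a lower number a stronger inhibitor), compound 1 gives 11000 nM, and compound 2 gives 8300 nM. The step of a 1.3-fold lower number from compound 1 to compound 2 (0.12 log units; within the scatter) does not separate them, so compound 2 stands nearest to compound 1, the two within the scatter of each other. Compound 3 `O=C(CCl)Nc1ccc(S(=O)(=O)Oc2ccccc2I)cc1` carries the change (chloromethyl in place of tert-butyl on a carbonyl carbon). Among the measured compounds shown here, no measured step brings in a chloromethyl group; the one known step, from compound 1 to compound 2, stayed within the scatter, so in this assay the expected step is a 1.0-fold lower number from compound 2 to compound 3 (0.02 log units; within the scatter), nothing beyond the scatter. Compound 3 is therefore estimated at 8000 nM, within 2000 nM to 30000 nM.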

Compound 3, half-maximal inhibitory concentration: 3900 nM
Estimate against measurement, compound 3: 2.1-fold (0.31 log units) above, and the stated range covers the measured number.
By their numbers in this assay, from the lowest: compound 3; then compounds 2 and 1 (each within the scatter of the next).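

In this assay, chloromethyl in place of tert-butyl on the carbonyl carbon gives a 2.1-fold lower number from compound 2 to compound 3 (0.33 log units; beyond the scatter), and chloro in place of butyl on the saturated chain carbon gives a 2.8-fold lower number from compound 1 to compound 3 (0.45 log units; beyond the scatter). Pentyl and tert-butyl could not be told apart, so this is the first change at this position to reach beyond the scatter, though both steps are modest. No measurement here explains the drop. Going by these compounds, the chlorine arrives together with a drop in heavy atoms, so its own part stays open. A plain methyl or a bromomethyl group on the same carbonyl carbon would help separate the two.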